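The source may report more compounds than this note shows. Statements on the series, on what has been measured and on what is new or still open speak of the compounds shown alone.

The set holds four compounds on a shared core, examined in a functional assay on HL-60 cells (Homo sapiens) for antiproliferative activity, read by MTT assay; on this read-out higher numbers stand for weaker inhibition and lower numbers for stronger inhibition. In this assay compound 1 `O[C@H]1CO[C@H](COCc2ccccc2)[C@@H](OCc2ccccc2)[C@@H]1OCc1ccccc1` was reported as "not active" (no number reported), with no number attached. Compound 2 `OCCC[C@@H]1O[C@H](COCc2ccccc2)[C@@H](OCc2ccccc2)[C@H](OCc2ccccc2)[C@H]1O` does give a number: in this assay compound 2 shows 19300 nM, which on this read-out is a weak effect. Compound 3 `CC[C@H]1O[C@H](COCc2ccccc2)[C@@H](OCc2ccccc2)[C@H](OCc2ccccc2)[C@H]1O` was reported in this assay as "not active" (no number reported) and, like compound 1, carries no number. Compound 3 therefore stands with compound 1 among the entries that have no value at all, while compound 2 is the only one with a measured figure, and a weak one.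

Compound 4 `CC[C@@H]1O[C@H](COCc2ccccc2)[C@@H](OCc2ccccc2)[C@H](OCc2ccccc2)[C@H]1O` is the next step. It differs from compound 3 in this way: the two compounds have the same atoms and bonds and differ only in configuration as drawn: 1 of 5 stereo elements differ; a stereocentre at a saturated ring carbon is drawn R in compound 3 and S in compound 4. Within the data shown here, no measured pair in this set shows what such a change does, so there is no step to lean on. Since compound 3 gave no measurable inhibition and compound 4 keeps every atom and bond, the expectation is that the step is no larger than the scatter in this assay, with compound 4 also likely to come back without a number. If a number is obtained, compound 4 is estimated at 40000 nM, within a range of 10000 nM to 150000 nM.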

Compound 4, half-maximal inhibitory concentration: 8200 nM
Beside the measured number, compound 4's estimate is 4.9-fold (0.69 log units) above it; the measured number lies below the stated range.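

In this assay, the configuration at this one saturated ring carbon separates a compound with a measurable effect from one without: compound 3, drawn R, is reported as "not active" (no number reported), whereas compound 4, drawn S, gives 8200 nM, which is still a weak effect. This contrast can be traced to that stereocentre alone, because nothing else separates the two structures: the fact that compounds 3 and 4 differ only in the configuration as drawn The chain gives a second result: with hydrogen in place of hydroxymethyl on a saturated chain carbon, two bonds along the chain from a saturated ring carbon, the step is a 2.4-fold lower number from compound 2 to compound 4 (0.37 log units; beyond the scatter), so the hydroxymethyl group is not required for activity in this pair.

The compounds shown offer only one pair of mirror-drawn configurations at this carbon, so it remains open whether drawing it S would give the same benefit with the chain of compound 2 or with a longer chain. From the compounds shown here alone, what an amine or a carboxylic acid on this chain would do to the activity in this assay also remains open.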